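Replacing a hydroxymethyl on a pyrimidine nucleoside with an enyne

The compounds below may be only part of what the source reports. "The series", "measured", "known", "first", "only" and "open" are said of these compounds alone.

Measured compounds:
- compound 1 `COc1ccccc1C(=O)/C=C/c1cc(=O)[nH]c(=O)n1COCCO`: 15200 nM
- compound 2 `O=c1[nH]c(=O)n([C@H]2C[C@H](O)[C@@H](CO)O2)cc1CO`: 9180 nM
- compound 3 `O=c1ccn([C@@H]2CCC[C@H]2CO)c(=O)[nH]1`: > 200000 nM

Three compounds share a pyrimidine-dione ring and were tested in an ADME assay on L1210/0 cells (Mus musculus) for cytotoxicity, with a stated time of 48 h; on this read-out higher numbers stand for weaker inhibition and lower numbers for stronger inhibition. Compound 1 gives 15200 nM in this assay. Compound 2 gives 9180 nM in this assay, and the gap between compound 2 and compound 1 is within the usual scatter, so the two cannot be ranked against each other. Compound 3 reaches only the limit of this assay, > 200000 nM, so no number is known for it; the limit of > 200000 nM in this assay, at which 1 of the 3 values shown sits, marks this limit.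

Compound 4 `C=CC#Cc1cn([C@H]2C[C@H](O)[C@@H](CO)O2)c(=O)[nH]c1=O` has not yet been measured. It differs from compound 2 in one place: a group of 4 heavy atoms (4 carbon; no ring) in place of a group of 2 heavy atoms (1 carbon, 1 oxygen; no ring), on an aromatic carbon. Among the measured compounds shown here, no step between two measured compounds shows what such a change does, so the expectation rests on the structural change alone. The step from compound 2 to compound 4 is expected to be modest, toward a lower number, a 3.1-fold lower number from compound 2 to compound 4 (0.49 log units; beyond the scatter). Compound 4 is therefore estimated to give 3000 nM in this assay, between 500 nM and 20000 nM.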

Compound 4, half-maximal inhibitory concentration: > 200000 nM
Compound 4 gave a limit, no number; the forecaster's own chance of this, stated with the estimate: 10%; middle value at least 66-fold (1.82 log units) away from the limit.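

In this assay, replacing the hydroxymethyl on this aromatic carbon with the enyne gives an at least 21-fold higher number from compound 2 to compound 4 (1.33 log units; beyond the scatter). Among the compounds shown here, this is the first step between two measured compounds here, and it shows that a change at this one position, with the rest of the molecule unchanged, can take away nearly all of the inhibition seen with compound 2. For compound 4, > 200000 nM is a limit and not a number, so the step has no upper end, and this compound too sits at the limit of the read-out: the limit of > 200000 nM in this assay, at which 2 of the 4 values shown sit.

The compounds shown leave open whether the loss of the hydroxymethyl or the arrival of the enyne matters more. They also leave open where other groups at this position, such as a methyl or a hydroxyethyl, would fall relative to compound 2 and compound 4.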